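Fluoro in place of methyl on compound 2

The compounds below may be only part of what the source reports. "The series", "measured", "known", "first", "only" and "open" are said of these compounds alone.

For the measured compounds named here, in a functional assay on KB cells (Homo sapiens) for antiproliferative activity, read by sulforhodamine B assay, with a stated time of 3 days (on this read-out higher numbers stand for an effect only at larger amounts of compound and lower numbers for an effect already at smaller amounts), compound 2 (`CCC1=C(O)c2c(oc(-c3ccc(OC)c(C)c3)cc2=O)C(CC)(CC)C1=O`) gives 28.5 uM, the only actual number so far. For compound 1 (`CCC1=C(O)c2c(oc(-c3ccc(Br)cc3)cc2=O)C(CC)(CC)C1=O`), the result is a limit, > 48.1 uM, and not a number.

Compound 3 (`CCC1=C(O)c2c(oc(-c3ccc(OC)c(F)c3)cc2=O)C(CC)(CC)C1=O`) carries fluoro in place of methyl on an aromatic carbon, ortho to a methoxy group: fluoro in place of methyl on an aromatic carbon.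

Going by the values given here, only one measured step bears on this change: an at least 1.6-fold lower number from compound 1 to compound 2 (0.22 log units; that floor lies within the scatter). It swaps the whole substituted phenyl group rather than this single position, and it rests on a limit, so it gives little guidance on size. With so little to go on, no step beyond the scatter is expected in this assay. The expected change is a 1.1-fold higher number from compound 2 to compound 3 (0.02 log units; within the scatter). Compound 3 is estimated at 30 uM, with an expected range from 13 uM to 54 uM.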

Compound 3, concentration for half-maximal effect: 26.7 uM
Estimate against measurement, compound 3: 1.1-fold (0.05 log units) above; measured number inside the range.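

In this assay, the change from methyl to fluoro on the aromatic carbon ortho to a methoxy group gives a 1.1-fold lower number from compound 2 to compound 3 (0.03 log units; within the scatter). For the compounds shown here, this is the first direct reading of this single position, and it shows that these two groups cannot be told apart here. The wider change from 4-bromophenyl to 3-fluoro-4-methoxyphenyl gives an at least 1.8-fold lower number from compound 1 to compound 3 (0.25 log units; that floor lies within the scatter), but this step starts from a limit and not from a number: the limit of > 48.1 uM in this assay, at which 1 of the 3 values shown sits.

From the compounds shown here alone, whether any group at this position can move the number beyond the scatter remains open, as only methyl and fluoro are compared here; an amine, a carboxylic acid or a longer chain such as propyl would test this. Going by these compounds, the role of the methoxy group also remains open, as compound 2 and compound 3 both carry it.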